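Larger Group on the Ring Nitrogen of Compound 1

This account rests on a few compounds, and the source may have more. Where it says the series, first, only, none or still open, it means among the compounds named here.

Compound 1 `Cn1sc2cc(OCc3cccc(-c4ccc(Cl)c(C(=O)O)c4)c3)ccc2c1=O`: 640 nM
Compound 2 `O=C(O)c1ccc(-c2cccc(COc3ccc4c(c3)CN(C3CCCC3)C4=O)c2)c(Cl)c1`: 110 nM

In an assay on HEK293 cells for positive allosteric modulation of metabotropic glutamate receptor 2 (Rattus norvegicus), read by thallium flux (on this read-out higher numbers stand for an effect only at larger amounts of compound and lower numbers for an effect already at smaller amounts), compound 1 gives 640 nM, the higher of the two numbers shown; compound 2 gives 110 nM, and the gap between them lies beyond the scatter. Compound 3 `CC(C)Cn1sc2cc(OCc3cccc(-c4ccc(Cl)c(C(=O)O)c4)c3)ccc2c1=O` differs from compound 1 by isopropyl in place of hydrogen on a saturated chain carbon bound to an aromatic nitrogen. For the measured compounds named here, no measured pair shows this exact change, so no direct step size is known. A modest shift toward a lower number is expected, estimated as a 1.8-fold lower number from compound 1 to compound 3 (0.26 log units; within the scatter), though the change could also stay within the scatter. Compound 3 is expected at about 350 nM, within a range from 100 nM to 1200 nM.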

Compound 3, half-maximal effective concentration: 470 nM
For compound 3 the middle estimate is 1.3-fold (0.13 log units) below the measured one; low and high end bracket the measured number.
By their numbers in this assay, from the lowest: compound 2; then compounds 3 and 1 (each within the scatter of the next).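

On the ring nitrogen of the core of compound 1, going from methyl to isobutyl gives a 1.4-fold lower number from compound 1 to compound 3 (0.13 log units; within the scatter) in this assay. This position therefore accepts the added isopropyl, and the change in chain size does not separate these two compounds beyond the usual variation between repeat measurements. No measurement at hand offers an explanation for this result. Still open, going by these compounds, is how a longer chain, an amine or a carboxylic acid at this place would read out on the same core.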